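The source may report more compounds than this note shows. Statements on the series, on what has been measured and on what is new or still open speak of the compounds shown alone.

In a functional assay on HeLa cells (Homo sapiens) for inhibition, read by MTT assay, with a stated time of 72 h (a lower number here means a stronger inhibitor, a higher number a weaker inhibitor), compound 1 `O=C(Nc1ccc(Oc2ncnc3[nH]ncc23)cc1)Nc1ccc(C(F)(F)F)cc1` gives > 10000 nM, which is a limit of the assay and not a number. Compound 2 `COc1cccc(NC(=O)Nc2ccc(Oc3ncnc4c3cnn4C)cc2)c1` gives > 10000 nM, and this too is only a limit. For the measured compounds named here, the record so far is therefore (the limit of > 10000 nM in this assay, at which 2 of the 2 values shown sit), and it offers no measured step between compounds from which to size a change. Compound 3 `Cn1ncc2c(Oc3ccc(NC(=O)Nc4ccc(C(F)(F)F)cc4)cc3)ncnc21` differs from compound 2 in one place, with 4-(trifluoromethyl)phenyl in place of 3-methoxyphenyl on an amide-type nitrogen. No change beyond the scatter is expected in this assay, in either direction, because compound 1 carries the same 4-(trifluoromethyl)phenyl and gives the limit > 10000 nM. The estimated step is a step that the limit leaves unreadable from compound 2 to compound 3. For compound 3 the expected value is 12000 nM, with an estimated range from 5000 nM to 30000 nM.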

Compound 3, half-maximal inhibitory concentration: > 10000 nM
Compound 3: no number, only a limit; the forecaster's own chance of this, stated with the estimate: 75%; the middle value lies beyond the limit too.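

No step can be read from compound 2 to compound 3 or from compound 1 to compound 3 in this assay, since all three compounds give a limit and not a number: the limit of > 10000 nM in this assay, at which 3 of the 3 values shown sit. The compounds shown leave open whether either change alters the inhibition at all.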